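Replacing ethyl with pyridin-2-yl on the nitrogen of compound 2

The source may report more compounds than this note shows. Statements on the series, on what has been measured and on what is new or still open speak of the compounds shown alone.

Measured in a functional assay on KB cells (Homo sapiens) for cytotoxicity, read by MTT assay, with a stated time of 3 days; on this read-out higher numbers stand for weaker inhibition and lower numbers for stronger inhibition
Compound 1 `N#Cc1c(NN)nc(SCc2nc3ccccc3[nH]2)nc1-c1ccccc1` gives 2.55 nM
Compound 2 `CCNc1nc(SCc2nc3ccccc3[nH]2)nc(-c2ccccc2)c1C#N` gives 7.35 nM

Compound 2 at 7.35 nM has the higher number of the two. Compound 3 `N#Cc1c(Nc2ccccn2)nc(SCc2nc3ccccc3[nH]2)nc1-c1ccccc1` carries pyridin-2-yl in place of ethyl on a nitrogen on an aromatic ring. Within the data shown here, the one measured step at this place (a 2.9-fold higher number from compound 1 to compound 2 (0.46 log units; beyond the scatter)) was modest, so no step beyond the scatter is expected in this assay and no direction can be relied on. The expected step (a 1.5-fold lower number from compound 2 to compound 3 (0.17 log units; within the scatter)) is small. For compound 3 the estimated value is 5 nM (range 1.5 nM to 20 nM).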

Compound 3, half-maximal inhibitory concentration: 7.35 nM
Compound 3: the middle estimate sits 1.5-fold (0.17 log units) below what was measured; the range from low to high includes it.
By their numbers in this assay, from the lowest: compound 1; then compounds 2 and 3 (each within the scatter of the next).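

In this assay, pyridin-2-yl on this nitrogen gives no change at the digits printed from compound 2 to compound 3 (within the scatter), so a six-membered aromatic ring with one hetero atom fits here as well as ethyl does. Set against amino, it gives a 2.9-fold higher number from compound 1 to compound 3 (0.46 log units; beyond the scatter), which matches the gap already seen for ethyl, so both replacements of amino end at the same number. Nothing at hand explains either step.

On these data alone, it remains open whether butyl or morpholine on this nitrogen would hold that number. A carboxylic acid on the pyridine ring is equally untested among the compounds shown.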